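This account rests on a few compounds, and the source may have more. Where it says the series, first, only, none or still open, it means among the compounds named here.

In an ADME assay on HepG2 cells (Homo sapiens) for cytotoxicity, with a stated time of 72 h (on this read-out higher numbers stand for an effect only at larger amounts of compound and lower numbers for an effect already at smaller amounts), compound 3 `Cc1cc(NC(=O)Nc2cccc(C(F)(F)F)c2)c2ccccc2n1` gives 21000 nM and compound 2 `COC(=O)c1cccc(NC(=O)Nc2cc(C)nc3ccccc23)c1` gives 23000 nM, two values within the usual scatter of each other. Compound 1 `Cc1cc(NC(=O)Nc2cccc([N+](=O)[O-])c2)c2ccccc2n1` gives only a limit, > 25000 nM. Compound 4 `COc1cccc(NC(=O)Nc2cc(C)nc3ccccc23)c1` differs from compound 3 by methoxy in place of trifluoromethyl on an aromatic carbon, with methoxy in place of trifluoromethyl on an aromatic carbon. The closest measured evidence comes from swaps at this same place: a 1.1-fold lower number from compound 2 to compound 3 (0.04 log units; within the scatter), an at least 1.0-fold lower number from compound 1 to compound 2 (0.03 log units; that floor lies within the scatter) and an at least 1.1-fold lower number from compound 1 to compound 3 (0.07 log units; that floor lies within the scatter). None of these steps clears the scatter, although none involves methoxy, so the expected step, a 1.0-fold higher number from compound 3 to compound 4 (0.02 log units; within the scatter), also stays within the scatter. For compound 4 the estimated value is 22000 nM, with an expected range of 11000 nM to 30000 nM.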

Compound 4, half-maximal effective concentration: > 25000 nM
Compound 4 ended at the assay's limit; the forecaster's own chance of this, stated with the estimate: 35%; middle value at least 1.1-fold (0.05 log units) away from the limit.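

In this assay, methoxy at this place gives an at least 1.1-fold higher number from compound 3 to compound 4 (0.07 log units; that floor lies within the scatter), and also an at least 1.0-fold higher number from compound 2 to compound 4 (0.03 log units; that floor lies within the scatter). The step between compound 1 and compound 4 cannot be read, so with methoxy added, no readable step at this position clears the scatter. The limit now recurs across this small set of compounds: the limit of > 25000 nM in this assay, at which 2 of the 4 values shown sit.

On these data alone, the true distance of compound 4 from compound 3 stays open, as its value is only a limit. Also open, as far as these compounds go, is whether an amine or a carboxylic acid here would give a clearly lower number.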